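Bromo on the Fused Core: Chloronitro and Nitrile Stilbenes

The source may report more compounds than this note shows. Statements on the series, on what has been measured and on what is new or still open speak of the compounds shown alone.

Measured compounds:
Compound 1, `O=[N+]([O-])c1ccc(Cl)c(/C=C/c2nc3ncccc3[nH]2)c1`, in a functional assay on SW-620 cells (Homo sapiens) for antiproliferative activity, read by MTT assay, with a stated time of 72 h (a lower number here means a stronger inhibitor, a higher number a weaker inhibitor), gives 52000 nM.
Compound 2, `O=[N+]([O-])c1ccc(Cl)c(/C=C/c2nc3ncc(Br)cc3[nH]2)c1`, in this assay gives 7990 nM.
Compound 3, `N#Cc1ccc(/C=C/c2nc3ncccc3[nH]2)cc1`, stands in this assay at a limit only: > 100000 nM.

Compound 1 and compound 2 share one core and differ by a single change, (bromo in place of hydrogen on an aromatic carbon). That change made the step of a 6.5-fold lower number from compound 1 to compound 2 (0.81 log units; beyond the scatter). Compound 3 carries a nitrile-bearing phenyl in place of the chloronitro-substituted phenyl; how the core of compound 3 differs from the core of compound 1 is not broken down here. For compound 3 the value is a limit of the assay, not a number, and it is the only one of the three measured compounds that sits at the limit of > 100000 nM in this assay, at which 1 of the 3 values shown sits.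

Compound 4, `N#Cc1ccc(/C=C/c2nc3ncc(Br)cc3[nH]2)cc1`, has not yet been measured. For the measured compounds named here, it differs from compound 3 by bromo in place of hydrogen on an aromatic carbon, which is the same kind of change as the one from compound 1 to compound 2, placed in the same words on the same position of the fused ring. Going by the values given here, the step it made there is the only guide available, and compound 3 starts from a limit rather than a number, so where compound 4 will land is uncertain. Compound 4 is expected to give roughly 60000 nM, somewhere between 15000 nM and 200000 nM. For compound 4 the estimated step is an at least 1.6-fold lower number from compound 3 to compound 4 (0.22 log units; that floor lies within the scatter), and this rests on a 6.5-fold lower number from compound 1 to compound 2 (0.81 log units; beyond the scatter) with the parent value taken at its limit. There is a real chance that compound 4 too is reported only as a limit.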

Compound 4, half-maximal inhibitory concentration: 7110 nM
Beside the measured number, compound 4's estimate is 8.4-fold (0.93 log units) above it; measured number outside the range, below it.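

In this assay, bromo in place of hydrogen on an aromatic carbon of the fused system again gave a lower number when carried from the chloronitro-substituted compounds to the nitrile-bearing ones, with an at least 14-fold lower number from compound 3 to compound 4 (1.14 log units; beyond the scatter). The change therefore points the same way on both cores, and each step lies beyond the scatter, but the comparison of their sizes remains unsettled: the same change on two cores in this assay, a 6.5-fold lower number (0.81 log units; beyond the scatter) from compound 1 to compound 2 and an at least 14-fold lower number (1.14 log units; beyond the scatter) from compound 3 to compound 4; the limit leaves it open whether they differ Compound 3 stands only at a limit of the assay, > 100000 nM, so its step is a floor rather than an exact size, and this pair of cores does not show that bromo would bring a similar gain on any further core.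

The compounds shown leave open whether chloro, methyl or an amine on the same aromatic carbon would lower the number as bromo does, and whether bromo would have a similar effect on another carbon of the fused system. They also leave open how the change would carry over to a core whose phenyl ring bears a carboxylic acid or a longer chain in place of the nitrile or the chloro and nitro groups.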